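Swapping Methyl for Fluoro on the Fused Ring

The source may report more compounds than this note shows. Statements on the series, on what has been measured and on what is new or still open speak of the compounds shown alone.

Measured compounds in an assay for inhibition of Polyunsaturated fatty acid 5-lipoxygenase (Homo sapiens), read by HPLC, with a stated time of 15 min; a lower number here means a stronger inhibitor, a higher number a weaker inhibitor:
- compound 1, `O=C(Nc1ccc(Cl)cc1)N1CCC(CO)CC1`: 2240 nM
- compound 2, `COc1cc(-c2nc3ccc(C)cn3c2NC2CCCCC2)ccc1OCCCNC(=O)Nc1ccc(C(F)(F)F)cc1`: 439 nM
- compound 3, `COc1cc(-c2nc3ccc(C)cn3c2NC2CCCCC2)ccc1OCCCNC(=O)Nc1ccc(OC(F)(F)F)cc1`: 116 nM

Compound 3 gives the lowest number of the three. Among the compounds with values here, the nearest is compound 2, and the one measured step, a 3.8-fold lower number from compound 2 to compound 3 (0.58 log units; beyond the scatter), concerns only the trifluoromethoxy end of the molecule. Compound 1 lies much higher still.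

Compound 4, `COc1cc(-c2nc3ccc(F)cn3c2NC2CCCCC2)ccc1OCCCNC(=O)Nc1ccc(OC(F)(F)F)cc1`, differs from compound 3 at the other end: fluoro in place of methyl on an aromatic carbon. No measured step touches this position, so nothing shown tells how this assay responds to a change there. Without such a guide, compound 4 is expected to stay close to compound 3, with the estimated step of a 1.3-fold higher number from compound 3 to compound 4 (0.11 log units; within the scatter) small and inside the usual scatter. The estimated value for compound 4 is 150 nM, within 50 nM to 450 nM.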

Compound 4, half-maximal inhibitory concentration: 696 nM
For compound 4 the middle estimate is 4.6-fold (0.67 log units) below the measured one; measured number above the stated range.
By their numbers in this assay, from the lowest: compound 3; then compounds 2 and 4 (each within the scatter of the next); then compound 1.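

On the six-membered aromatic ring of the fused system, this position clearly matters in this assay: fluoro in place of methyl gives a 6.0-fold higher number from compound 3 to compound 4 (0.78 log units; beyond the scatter) although just one heavy atom changes and the donor and acceptor counts stay the same. A single swap here can therefore shift the number as well as a change at the trifluoromethoxy end. Nothing available explains why the number rises. Still open, from the compounds shown here alone, is how a chloro or ethyl group would behave at this position. Also open, going by these compounds, is whether fluoro would have the same effect with trifluoromethyl at the other end.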